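The source may report more compounds than this note shows. Statements on the series, on what has been measured and on what is new or still open speak of the compounds shown alone.

Measured in a functional assay on MCF7 cells (Homo sapiens) for inhibition, read by MTT assay, with a stated time of 72 h, tested at 30 uM; a lower number here means less inhibition of growth, a higher number more inhibition of growth at the concentration tested:
- compound 1 `C=CCc1ccc(OCc2cn(-c3ccc(C#N)cc3)nn2)c(O)c1`: 35.7%
- compound 2 `C=CCc1ccc(OCc2cn(-c3ccccc3CO)nn2)c(O)c1`: 34.5%
- compound 3 `C=CCc1cc(O)c(O)c(CN2CCC(CO)CC2)c1`: 26.2%

Compound 2, at 34.5%, lies within the scatter of both compound 1 and compound 3, so these three numbers give no ranking in this assay.

The next compound to be tested is compound 4 `C=CCc1ccc(OCc2cn(-c3ccc(Br)cc3)nn2)c(O)c1`. It differs from compound 2 at a single place, with 4-bromophenyl in place of 2-(hydroxymethyl)phenyl on an aromatic nitrogen.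

Going by the values given here, one measured step bears on this change: a number 1.2 percentage points lower from compound 1 to compound 2 (within the scatter). That step also exchanges the group on this aromatic nitrogen, and it stays within the scatter. Compound 3 offers no comparison at this place, since no single change links it to compound 2. Among the compounds with values here, no measured compound yet carries 4-bromophenyl, so the expectation rests on that one small step alone.

A step beyond the scatter is therefore not expected in this assay, and no clear direction can be assigned. The expected step, a number 1.5 percentage points higher from compound 2 to compound 4 (within the scatter), is no larger than the scatter. For compound 4 the estimated value is 36%, with an expected range from 26% to 47%.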

Compound 4, percent growth inhibition at one concentration: 19.4%
Compound 4: middle estimate off by 16.6 percentage points, on the high side, and the stated range ends above it.
By their numbers in this assay, from the lowest: compounds 4, 3, 2 and 1 (each within the scatter of the next, the first and the last beyond it).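

In this assay, the group on the aromatic nitrogen turned out to matter, which the earlier exchange of 4-cyanophenyl for 2-(hydroxymethyl)phenyl had not shown: 4-bromophenyl in place of 2-(hydroxymethyl)phenyl gives a number 15.1 percentage points lower from compound 2 to compound 4 (beyond the scatter), a change beyond the scatter. The cleaner comparison concerns a single substituent on that phenyl ring, where bromo in place of cyano gives a number 16.3 percentage points lower from compound 1 to compound 4 (beyond the scatter), so these two groups are not interchangeable in this assay, although both steps remain modest. No available evidence explains why bromo gives the lower number.

The compounds shown leave open whether this lower number is particular to bromo or would also appear with other groups on the phenyl ring, such as chloro, methoxy, an amine or a carboxylic acid. They also leave open how much of the step from the 2-(hydroxymethyl)phenyl compound depends on the identity of the substituent and how much on where it sits, and a 4-(hydroxymethyl)phenyl group on the same nitrogen would separate the two.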